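Methoxy to ethoxy on a pair at the assay limit

A few compounds are considered here, and "the series" means these few. Any claim that something is new, unique, unknown or untested is made for them only; others in the source may bear on it.

Compound 1 `COc1nc2c(c(=O)n(C)c(=O)n2C)n1CC(=O)NCc1ccccc1Cl` stands at the edge of what an assay on isolated protein for inhibition of high affinity 3',5'-cyclic-AMP phosphodiesterase 7A (Homo sapiens), read by cAMP accumulation, with a stated time of 10 min (a lower number here means a stronger inhibitor, a higher number a weaker inhibitor), can report: in this assay compound 1 gives > 200000 nM, which is a limit of the measurement and not a number. Compound 2 `COc1nc2c(c(=O)n(C)c(=O)n2C)n1CCCC(=O)NCc1ccccc1Cl` also returns only a limit in this assay, > 200000 nM. Both values sit at the limit of > 200000 nM in this assay, at which 2 of the 2 values shown sit, so on the numbers shown compound 1 cannot be ranked against any other member of the series. Compound 3 `CCOc1nc2c(c(=O)n(C)c(=O)n2C)n1CC(=O)NCc1ccccc1Cl` differs from compound 1 by methyl in place of hydrogen on a saturated chain carbon bound to an oxygen on an aromatic ring. Going by the values given here, no measured step covers this change. The expected step from compound 1 to compound 3 is a step that the limit leaves unreadable from compound 1 to compound 3, that is, none beyond the scatter. Compound 3 is estimated in this assay at 300000 nM, with a range from 50000 nM to 2000000 nM, and is expected most likely to be reported again only as a limit.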

Compound 3, half-maximal inhibitory concentration: > 200000 nM
Compound 3: no number, only a limit; the forecaster's own chance of this, stated with the estimate: 85%; the middle value is on the limit's open side.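

No step can be read from compound 1 to compound 3, as compound 3 in this assay gives only a limit, > 200000 nM: the limit of > 200000 nM in this assay, at which 3 of the 3 values shown sit.

The compounds shown leave open whether any member of this series has a measurable half-maximal inhibitory concentration in this assay.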